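Purine series: benzyl to methyl and Vero tolerance

The compounds below may be only part of what the source reports. "The series", "measured", "known", "first", "only" and "open" are said of these compounds alone.

Measured so far:
Compound 1 `Oc1cccc(Nc2nc(NCc3ccccc3)nc3[nH]cnc23)c1` — in an ADME assay on Vero cells (Chlorocebus sabaeus) for cytotoxicity (a lower number here means that less compound is tolerated, a higher number that more compound is tolerated), compound 1 gives > 150000 nM, which is a limit of the assay rather than a number.
Compound 2 `CC(=O)c1ccc(Nc2nc(NCCO)nc3[nH]cnc23)cc1` — in this assay compound 2 gives 160000 nM.

For compound 1 only a limit is known, so no number can be set for it; it sits at the limit of > 150000 nM in this assay, at which 1 of the 2 values shown sits. Going by the values given here, compound 2 is the one member with a number, and that number lies close to the limit at which compound 1 sits. Among the compounds with values here, no step between two measured compounds that differ in a single place is available.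

Compound 3 `CNc1nc(Nc2cccc(O)c2)c2nc[nH]c2n1` is to be measured next. Against compound 1 it shows (hydrogen in place of phenyl on a saturated chain carbon bound to a nitrogen on an aromatic ring). Within the data shown here, with no measured step to lean on, no change beyond the scatter is expected in this assay; compound 3 is likely to remain at or past the limit. The expected step is a step that the limit leaves unreadable from compound 1 to compound 3, within the scatter. The expected reading for compound 3 is 180000 nM, in a range of 90000 nM to 400000 nM.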

Compound 3, half-maximal cytotoxic concentration: 168000 nM
For compound 3 the middle estimate is 1.1-fold (0.03 log units) above the measured one, within the range that was stated.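

The step from compound 1 to compound 3 cannot be read, because compound 1 carries only a limit, not a number: the limit of > 150000 nM in this assay, at which 1 of the 3 values shown sits. Whether benzyl to methyl changes the reading in this assay stays open for the compounds shown.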